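The source may report more compounds than this note shows. Statements on the series, on what has been measured and on what is new or still open speak of the compounds shown alone.

In an assay on isolated protein for inhibition of long-chain fatty acid transport protein 1 (Mus musculus) (on this read-out higher numbers stand for weaker inhibition and lower numbers for stronger inhibition), three close analogues have been measured. Compound 1 `CCC(=O)c1ccc(N(C)C(=O)CSc2nnc(CNc3ccccc3)n2CC)cc1` gives 2000 nM, compound 2 `CCc1ccc2oc(CSc3nnc(CNc4ccccc4)n3CC)nc2c1` gives 1800 nM, and compound 3 `CCOC(=O)c1ccc(NC(=O)CSc2nnc(CNc3ccccc3)n2CC)cc1` gives 1100 nM. Compound 2 thus stands second highest of the three numbers, with compound 1 within the scatter of it and compound 3 likewise within the scatter, so none of the three can be set apart from the others on these data. Compound 4 `CCC(O)c1ccc2oc(CSc3nnc(CNc4ccccc4)n3CC)nc2c1` differs from compound 2 by 1-hydroxypropyl in place of ethyl on an aromatic carbon. Going by the values given here, no step between measured compounds is known here, so the size and direction of this change rest on expectation alone. The expected step is no change at the digits printed from compound 2 to compound 4 (within the scatter), staying within the scatter. Compound 4 is expected at 1800 nM, with a range from 600 nM to 5400 nM.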

Compound 4, half-maximal inhibitory concentration: 3700 nM
The estimate for compound 4 lay 2.1-fold (0.31 log units) below the measured number, and the stated range covers the measured number.
By their numbers in this assay, from the lowest: compounds 3, 2, 1 and 4 (each within the scatter of the next, the first and the last beyond it).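

Swapping ethyl for 1-hydroxypropyl on this aromatic carbon gives a 2.1-fold higher number from compound 2 to compound 4 (0.31 log units; beyond the scatter) in this assay, the first change among these compounds that can be read beyond the scatter. The position therefore responds to this substitution, with modestly weaker inhibition, but inhibition is not lost. No accompanying data explain the shift. Going by these compounds, it remains open whether the hydroxyl or the longer chain drives the step, as a plain propyl group would help to show. On these data alone, how an amine or a carboxylic acid on this carbon would read also remains open.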